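The source may report more compounds than this note shows. Statements on the series, on what has been measured and on what is new or still open speak of the compounds shown alone.

Among the measured compounds shown here, in a functional assay on the whole organism with Mus musculus as the target (on this read-out lower numbers stand for an effect already at smaller amounts and higher numbers for an effect only at larger amounts of compound), two related compounds have numbers so far. Compound 1 (`CCCC(=O)OC1CCN(c2ccc(-c3ccc(Cl)cc3Cl)nn2)CC1`) gives 31 mg/kg, and compound 2 (`CNC(=O)OC1CCN(c2ccc(-c3ccccc3Cl)nn2)CC1`) gives 13 mg/kg. Compound 2 therefore holds the lower of the two numbers, with a gap beyond the usual scatter, so it shows its effect at the smaller dose.

Compound 3 (`CNC(=O)OC1CCN(c2ccc(-c3ccc(Cl)cc3Cl)nn2)CC1`) is compound 2 with a single change: chloro in place of hydrogen on an aromatic carbon. In words, this is chloro in place of hydrogen on an aromatic carbon, meta to a chloro group and para to a large group, which turns 2-chlorophenyl into 2,4-dichlorophenyl.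

For the measured compounds named here, no measured pair isolates this change. Compound 3 shares the 2,4-dichlorophenyl group with compound 1, but the two differ elsewhere, so the 31 mg/kg of compound 1 offers only a weak hint towards a higher number. No shift beyond the scatter is expected, only a slight upward drift at most. The estimated change is small, a 1.2-fold higher number from compound 2 to compound 3 (0.09 log units; within the scatter). For compound 3 the expected value is 16 mg/kg, with an estimated range of 6 mg/kg to 40 mg/kg.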

Compound 3, dose for half-maximal effect: 1.4 mg/kg
Estimate against measurement, compound 3: 11-fold (1.06 log units) above, and the stated range ends above it.
By their numbers in this assay, from the lowest: compound 3; then compound 2; then compound 1.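

In this assay, chloro in place of hydrogen on the aromatic carbon para to a large group, which turns 2-chlorophenyl into 2,4-dichlorophenyl, gives a 9.3-fold lower number from compound 2 to compound 3 (0.97 log units; beyond the scatter) and so lies well beyond the usual scatter, showing that this single added atom at this position matters for the dose needed. With 2,4-dichlorophenyl held fixed, methylamino in place of propyl on the carbonyl carbon gives a 22-fold lower number from compound 1 to compound 3 (1.35 log units; beyond the scatter) in this comparison, so the 2,4-dichlorophenyl group of compound 1 does not by itself bring a high number, and the group on the carbonyl carbon has a large influence on the outcome. No measurement at hand explains why either change has this effect.

Chloro is the only group seen at this position, so it remains open whether fluoro, methyl or methoxy there would lower the number as well. From the compounds shown here alone, it is also open whether a group such as ethylamino or dimethylamino on the carbonyl carbon would keep the low number of compound 3 or whether 4-chlorophenyl alone would be enough.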